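The source may report more compounds than this note shows. Statements on the series, on what has been measured and on what is new or still open speak of the compounds shown alone.

Compound 1 `CC(C)(C)c1ccc(OCCCON2C(N)=NC(N)=NC23CCSCC3)cc1`: 1 nM
Compound 2 `NC1=NC2(CCSCC2)N(OCCCOc2cccc(Cl)c2)C(N)=N1`: 130 nM
Compound 3 `NC1=NC2(CCSCC2)N(OCCCOc2ccccc2Cl)C(N)=N1`: 80 nM

All three values come from a functional assay on MDA-MB-231 cells (Homo sapiens) for antiproliferative activity, read by MTT assay, with a stated time of 72 h; a higher number here means a weaker inhibitor, a lower number a stronger inhibitor. Compound 3, at 80 nM, cannot be told apart from compound 2 at this level of scatter, and both numbers lie far above that of compound 1, at 1 nM.

The next compound to consider is compound 4 `COc1ccc(OCCCON2C(N)=NC(N)=NC23CCSCC3)cc1`. It carries 4-methoxyphenyl in place of 2-chlorophenyl on an oxygen on a saturated carbon.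

For the measured compounds named here, only one measured step links two compounds that differ in one place: a 1.6-fold lower number from compound 2 to compound 3 (0.21 log units; within the scatter). It exchanges one chlorophenyl group for another and stays within the scatter, so it says little about removing the chlorine altogether. Going by the values given here, the only other guide is compound 1, the one measured compound without chlorine on its phenyl ring, at 1 nM. That is a single compound with a different group, so it supports the direction of a change better than its size.

A lower number is therefore expected in this assay, covering only part of that gap. The expected change is a 2.7-fold lower number from compound 3 to compound 4 (0.43 log units; beyond the scatter). Compound 4 is estimated at 30 nM, with an expected range from 5 nM to 150 nM.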

Compound 4, half-maximal inhibitory concentration: 350 nM
Beside the measured number, compound 4's estimate is 12-fold (1.07 log units) below it, outside the stated range (above it).
By their numbers in this assay, from the lowest: compound 1; then compounds 3 and 2 (each within the scatter of the next); then compound 4.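

In this assay, removing the chlorine did not bring the number down: 4-methoxyphenyl in place of 2-chlorophenyl gives a 4.4-fold higher number from compound 3 to compound 4 (0.64 log units; beyond the scatter) and 4-methoxyphenyl in place of 3-chlorophenyl gives a 2.7-fold higher number from compound 2 to compound 4 (0.43 log units; beyond the scatter) so both exchanges lead upward and beyond the scatter. The comparison with compound 1 is far larger, with methoxy in place of tert-butyl on an aromatic carbon giving a 350-fold higher number from compound 1 to compound 4 (2.54 log units; beyond the scatter) and showing that a phenyl ring without chlorine is not enough for a low number, since the group carried on that ring makes a great difference among these compounds. The data shown offer no measured explanation for either the rise or the large gap.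

As far as these compounds go, with only methoxy and tert-butyl to compare on that aromatic carbon, it remains open how the number would respond to ethyl, isopropyl, trifluoromethyl or an unsubstituted phenyl ring. A 4-chlorophenyl group would also help to separate the effect of chlorine from that of its place on the ring, while an amine or a carboxylic acid there would test a quite different kind of group.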